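Removing the nitro group from compound 3

The source may hold more compounds than are shown below. What is called first, only, known or untested is meant among the compounds shown, and "the series" means these compounds.

Measured in a functional assay on HCT-116 cells (Homo sapiens) for antiproliferative activity, read by MTT assay (on this read-out lower numbers stand for stronger inhibition and higher numbers for weaker inhibition), so far:
compound 1 `Cn1c(=O)c(=O)n(C2CCCC2)c2nc(N/N=C/c3ccc(F)c(Cl)c3)ncc21` gives 9020 nM
compound 2 `COc1ccc(/C=N/Nc2ncc3c(n2)n(C2CCCC2)c(=O)c(=O)n3C)cc1` gives 36100 nM
compound 3 `Cn1c(=O)c(=O)n(C2CCCC2)c2nc(N/N=C/c3cc([N+](=O)[O-])ccc3Cl)ncc21` gives 5610 nM

Compound 3 sits at the low end of this small set, but it shares that end with the 3-chloro-4-fluorophenyl member (the gap is a 1.6-fold lower number from compound 1 to compound 3 (0.21 log units; within the scatter)). It stands clear of the 4-methoxyphenyl member (the gap is a 6.4-fold lower number from compound 2 to compound 3 (0.81 log units; beyond the scatter)).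

The next member is compound 4 `Cn1c(=O)c(=O)n(C2CCCC2)c2nc(N/N=C/c3ccccc3Cl)ncc21`, with hydrogen in place of nitro on an aromatic carbon. Among the measured compounds shown here, no measured pair isolates this change. The closest evidence is a 1.6-fold lower number from compound 1 to compound 3 (0.21 log units; within the scatter), which joins a chlorophenyl member without nitro to one with it. The larger steps, a 4.0-fold higher number from compound 1 to compound 2 (0.60 log units; beyond the scatter) and a 6.4-fold lower number from compound 2 to compound 3 (0.81 log units; beyond the scatter), both involve the 4-methoxyphenyl member, which carries no chloro group, and so bear on the change less directly.

A small rise in the number is therefore expected, close to the scatter, and the estimated step is a 1.6-fold higher number from compound 3 to compound 4 (0.21 log units; within the scatter). For compound 4 the estimated value is 9000 nM, with an expected range of 3500 nM to 25000 nM.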

Compound 4, half-maximal inhibitory concentration: 14000 nM
For compound 4 the middle estimate is 1.6-fold (0.19 log units) below the measured one; the measured number falls inside the stated range.
By their numbers in this assay, from the lowest: compounds 3, 1 and 4 (each within the scatter of the next, the first and the last beyond it); then compound 2.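

In this assay, the 2-chlorophenyl pair now isolates the nitro group para to a chloro group, and removing it gives a step beyond the scatter, though a modest one (a 2.5-fold higher number from compound 3 to compound 4 (0.40 log units; beyond the scatter)). Without nitro, the 2-chlorophenyl member still stands clear of the 4-methoxyphenyl member (a 2.6-fold lower number from compound 2 to compound 4 (0.41 log units; beyond the scatter)), while its gap to the 3-chloro-4-fluorophenyl member stays within the scatter (a 1.6-fold higher number from compound 1 to compound 4 (0.19 log units; within the scatter)). No available evidence accounts for the step between nitro and hydrogen at this position.

Open, going by these compounds, is whether a nitrile, an amine or a carboxylic acid at this place would read closer to nitro or to hydrogen. Also open, on these data alone, is how the nitro group would read on a ring that lacks the chloro group.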